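From Ester Oxygen to Sulfonamide Nitrogen on the Saturated Ring

The compounds below may be only part of what the source reports. "The series", "measured", "known", "first", "only" and "open" are said of these compounds alone.

Of the compounds shown here, three of one series have been tested in an ADME assay on Vero cells (Chlorocebus sabaeus) for cytotoxicity, read by MTT assay, with a stated time of 48 h; on this read-out higher numbers stand for weaker inhibition and lower numbers for stronger inhibition. Compound 1 `COc1ccccc1C(=O)OC1CCC(CN2CCN(c3cc(=O)c4cc(C(F)(F)F)cc([N+](=O)[O-])c4s3)CC2)CC1` carries a ((2-methoxyphenyl)carbonyl)oxy group on a saturated ring carbon, and in this assay compound 1 reaches only the limit of > 64 ug/mL. Compound 2 `O=C(NC1CCC(CN2CCN(c3cc(=O)c4cc(C(F)(F)F)cc([N+](=O)[O-])c4s3)CC2)CC1)c1ccccc1` bears benzamido in that position, and in this assay compound 2 gives 44.3 ug/mL. Compound 3 `COc1cccc(C(=O)OC2CCC(CN3CCN(c4cc(=O)c5cc(C(F)(F)F)cc([N+](=O)[O-])c5s4)CC3)CC2)c1` carries ((3-methoxyphenyl)carbonyl)oxy, and in this assay compound 3 likewise sits at the limit of > 64 ug/mL. Going by the values given here, compound 3 therefore stands with compound 1 at the edge of what the assay records (the limit of > 64 ug/mL in this assay, at which 2 of the 3 values shown sit), while compound 2 supplies the only plain number. The step of an at least 1.4-fold higher number from compound 2 to compound 3 (0.15 log units; that floor lies within the scatter) is a floor within the scatter, as is an at least 1.4-fold lower number from compound 1 to compound 2 (0.15 log units; that floor lies within the scatter), and the step that the two limits leave unreadable from compound 1 to compound 3 cannot be read at all.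

Compound 4 `O=c1cc(N2CCN(CC3CCC(NS(=O)(=O)c4ccccc4)CC3)CC2)sc2c([N+](=O)[O-])cc(C(F)(F)F)cc12` is compound 3 with (phenylsulfonyl)amino in place of ((3-methoxyphenyl)carbonyl)oxy on a saturated ring carbon. Among the compounds with values here, the step that bears on this change is the one from compound 2 to compound 3, where a group with one hydrogen-bond donor gave way to one with none and the number rose only to a floor within the scatter. Returning to a group that carries one hydrogen-bond donor is expected to give an at least 1.2-fold lower number from compound 3 to compound 4 (0.10 log units; that floor lies within the scatter), a step within the scatter. Compound 4 is accordingly estimated at 50 ug/mL, ranging from 25 ug/mL to 100 ug/mL, with a fair chance that this assay again reports only a limit.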

Compound 4, half-maximal inhibitory concentration: > 64 ug/mL
Compound 4: a limit, no number; the forecaster's own chance of this, stated with the estimate: 45%; at least 1.2-fold (0.10 log units) between middle value and limit.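

With the sulfonamide, a group carrying a hydrogen-bond donor on the saturated ring carbon still ends at a limit, so in this assay compound 4 gives > 64 ug/mL, which is a limit and not a number. Placing phenylsulfonyl in place of benzoyl on the amine nitrogen, the one comparison here with a readable bound, gives an at least 1.4-fold higher number from compound 2 to compound 4 (0.15 log units; that floor lies within the scatter), so the hydrogen-bond donor shared by compound 2 and compound 4 does not by itself secure a plain number, and the floor does not show how far apart the two compounds lie. The steps from compound 3 and from compound 1 to compound 4 cannot be read, since both ends of each are limits, and the series now gathers largely at one reading: the limit of > 64 ug/mL in this assay, at which 3 of the 4 values shown sit.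

How far compound 1, compound 3 and compound 4 actually lie from compound 2 remains unknown, and so does any ranking among these three. Also open, as far as these compounds go, is whether a primary amine, a carboxylic acid or a longer alkyl chain on the same saturated ring carbon would give a plain number in this assay or would again reach the limit.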